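This account rests on a few compounds, and the source may have more. Where it says the series, first, only, none or still open, it means among the compounds named here.

Compound 1 `CN1CCc2nc(C#Cc3cccc(F)c3)sc2C1` and compound 2 `CC1CC(C(=O)N2CCc3nc(C#Cc4ccccc4)sc3C2)C1` share a common core, and both were tested in an assay on HEK293 cells for negative allosteric modulation of metabotropic glutamate receptor 5 (Homo sapiens), read by FLIPR, with a stated time of 1 h; on this read-out lower numbers stand for stronger inhibition and higher numbers for weaker inhibition. For compound 1 the read-out is only a limit of the assay, > 10000 nM. Compound 2 likewise gives only a limit in this assay, > 10000 nM. Within the data shown here, compound 2 therefore stands at the edge of what the assay can report: no number is known for it, and the one other value shown sits at the same limit, (the limit of > 10000 nM in this assay, at which 2 of the 2 values shown sit). Compound 3 `Cc1nc(C(=O)N2CCc3nc(C#Cc4ccccc4)sc3C2)cs1` has not yet been measured in this assay. It differs from compound 2 at a single place: 2-methyl-1,3-thiazol-4-yl in place of 3-methylcyclobutyl on a carbonyl carbon. Among the measured compounds shown here, no step between two measured compounds is known, so the size of this change cannot be read from any measured pair. Compound 3 is expected to show a step of an at least 2.0-fold lower number from compound 2 to compound 3 (0.30 log units; that floor lies within the scatter), which may well stay within the scatter and leave compound 3 at the same limit. The estimate for compound 3 in this assay is 5000 nM, with a range from 800 nM to 30000 nM.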

Compound 3, half-maximal inhibitory concentration: > 10000 nM
Compound 3 ended at the assay's limit; the forecaster's own chance of this, stated with the estimate: 60%; middle value at least 2.0-fold (0.30 log units) from the limit.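

No step from compound 2 to compound 3 can be read in this assay, because both compounds give only a limit of the assay: the limit of > 10000 nM in this assay, at which 3 of the 3 values shown sit.

The compounds shown leave open what number any of them would have, and whether any change on the shared core gives a measurable inhibition.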